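Replacing a tert-butylphenyl with a hydroxymethylphenyl on the ring

The compounds below may be only part of what the source reports. "The series", "measured", "known", "first", "only" and "open" are said of these compounds alone.

Compound 1 `CC(C)c1cccc(C(C)C)c1NC(=O)NCC1(c2ccc(C(C)(C)C)cc2)CCCC1`: 63 nM
Compound 2 `CC(C)c1cccc(C(C)C)c1NC(=O)NCC1(c2cccc(C(=O)O)c2)CCCC1`: 620 nM

Among the measured compounds shown here, in an assay on microsomes for inhibition of acyl-CoA:cholesterol acyltransferase (Oryctolagus cuniculus) (a lower number here means a stronger inhibitor, a higher number a weaker inhibitor), compound 1 gives the lowest of the two numbers; its only neighbour is compound 2, reached by a 9.8-fold higher number from compound 1 to compound 2 (0.99 log units; beyond the scatter). Compound 3 `CC(C)c1cccc(C(C)C)c1NC(=O)NCC1(c2cccc(CO)c2)CCCC1` differs from compound 1 as follows: 3-(hydroxymethyl)phenyl in place of 4-(tert-butyl)phenyl on a saturated ring carbon. For the measured compounds named here, the one measured step that bears on this change is a 9.8-fold higher number from compound 1 to compound 2 (0.99 log units; beyond the scatter), which also removes the 4-(tert-butyl)phenyl. A loss of the same kind but smaller is therefore expected, namely a 4.8-fold higher number from compound 1 to compound 3 (0.68 log units; beyond the scatter). Compound 3 is estimated at 300 nM, with a range from 100 nM to 1000 nM.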

Compound 3, half-maximal inhibitory concentration: 15 nM
For compound 3 the middle estimate is 20-fold (1.30 log units) above the measured one; measured number outside the range, below it.
By their numbers in this assay, from the lowest: compound 3; then compound 1; then compound 2.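

The 4-(tert-butyl)phenyl is not needed for a low number at this saturated ring carbon: 3-(hydroxymethyl)phenyl in its place gives a 4.2-fold lower number from compound 1 to compound 3 (0.62 log units; beyond the scatter). On the aromatic carbon, hydroxymethyl in place of carboxy gives a 41-fold lower number from compound 2 to compound 3 (1.62 log units; beyond the scatter), so the loss seen with compound 2 cannot be read as a general cost of removing the 4-(tert-butyl)phenyl. No measurement here explains why hydroxymethyl and carboxy differ so widely. Going by these compounds, how a methoxymethyl or an aminomethyl group would compare with hydroxymethyl at this place remains open.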